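Methylsulfanyl in Place of Propyl on the Shared Core

This account rests on a few compounds, and the source may have more. Where it says the series, first, only, none or still open, it means among the compounds named here.

Compound 3 `CCCc1nc(N)c2nc(O)n(Cc3ccccc3)c2n1` gives 3 mg/kg in a functional assay on the whole organism for activation, with Mus musculus as the target (a lower number here means that less compound is needed, a higher number that more compound is needed for the effect), the highest of the three numbers here: compound 1 `Nc1nc(O)nc2c1nc(O)n2Cc1ccccc1` gives 1 mg/kg and compound 2 `CCCCc1nc(N)c2nc(O)n(Cc3ccccc3)c2n1` gives 0.3 mg/kg. Compound 4 `CSc1nc(N)c2nc(O)n(Cc3ccccc3)c2n1` differs from compound 3 at one place: methylsulfanyl in place of propyl on an aromatic carbon. Within the data shown here, two measured steps touch that same aromatic carbon. Changing what sits there moved the number a 3.0-fold higher number from compound 1 to compound 3 (0.48 log units; beyond the scatter) and a 10-fold higher number from compound 2 to compound 3 (1.00 log units; beyond the scatter), so this position clearly matters, though neither step involves a sulfur-bearing group and the direction for methylsulfanyl cannot be read directly. Since compound 3 sits at the top of the range, a lower number is expected for compound 4, a 3.0-fold lower number from compound 3 to compound 4 (0.48 log units; beyond the scatter), giving an estimate of 1 mg/kg with a likely range from 0.3 mg/kg to 3 mg/kg.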

Compound 4, minimum effective dose: 0.1 mg/kg
The estimate for compound 4 lay 10-fold (1.00 log units) above the measured number, outside the stated range (below it).
By their numbers in this assay, from the lowest: compound 4; then compound 2; then compound 1; then compound 3.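

Every group shown at this aromatic carbon gives a lower number than propyl, but methylsulfanyl goes furthest, with a 30-fold lower number from compound 3 to compound 4 (1.48 log units; beyond the scatter) and then a 3.0-fold lower number from compound 2 to compound 4 (0.48 log units; beyond the scatter) and a 10-fold lower number from compound 1 to compound 4 (1.00 log units; beyond the scatter) as its other steps. Since both the longer butyl and the smaller methylsulfanyl lower the number from propyl, chain length alone does not order these compounds. Nothing available explains the gain from methylsulfanyl.

The compounds shown leave open whether the sulfur or the small size of the group counts, and methoxy and ethylsulfanyl on this carbon would help separate the two. On these data alone, how an amine there would compare also remains open.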